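Trading a sulfonamide for a methyl on the aryl piperazine

This account rests on a few compounds, and the source may have more. Where it says the series, first, only, none or still open, it means among the compounds named here.

Two compounds share a core that carries a dichlorobenzyl ether and a benzylamine. Compound 1 `CS(=O)(=O)N1CCC2(CCN(C(=O)[C@H](COCc3ccc(Cl)c(Cl)c3)NCc3ccccc3)CC2)C1` has a spiro-fused amine capped with a methanesulfonyl group, and in an assay on CHO cells for displacement of a labelled ligand from Substance-P receptor (Homo sapiens) (on this read-out lower numbers stand for stronger inhibition and higher numbers for weaker inhibition), compound 1 gives 2500 nM. Compound 2 `CS(=O)(=O)Nc1ccccc1N1CCN(C(=O)[C@H](COCc2ccc(Cl)c(Cl)c2)NCc2ccccc2)CC1` instead carries an aryl piperazine bearing a methanesulfonamido group, and in this assay compound 2 gives 4.8 nM, the lowest of the two numbers, far beyond the scatter from compound 1. Since the two differ in more than one place, the gap is simply what their values show.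

Compound 3 `Cc1ccccc1N1CCN(C(=O)[C@H](COCc2ccc(Cl)c(Cl)c2)NCc2ccccc2)CC1` keeps the aryl piperazine but makes one change: methyl in place of methanesulfonamido on an aromatic carbon. Within the data shown here, nothing among the measured pairs isolates this change, so the step of a 3.1-fold higher number from compound 2 to compound 3 (0.49 log units; beyond the scatter) is only an expectation, a moderate loss of potency. Compound 3 is therefore estimated at 15 nM, likely between 3 nM and 80 nM.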

Compound 3, half-maximal inhibitory concentration: 558 nM
Compound 3: middle estimate off by 37-fold (1.57 log units), on the low side; measured number above the stated range.
By their numbers in this assay, from the lowest: compound 2; then compound 3; then compound 1.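

In this assay, among these compounds, replacing methanesulfonamido with methyl gives a 120-fold higher number from compound 2 to compound 3 (2.07 log units; beyond the scatter), the first step here that isolates a single place, and a large one. Keeping the aryl piperazine is therefore not enough to keep the low number of compound 2: the result also depends heavily on the group on this aromatic carbon, ortho to a large group. The change swaps five heavy atoms, including a hydrogen-bond donor and two acceptors, for a single carbon, but nothing measured here explains why the step is so large.

Going by these compounds, it remains open how an amine, a methoxy group or an acetamido group in this place would compare, and so which part of methanesulfonamido the step follows. On these data alone, whether the step keeps its size with another group in place of the benzylamine also remains open.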